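Series notes: from compound 1 to compound 4

This account rests on a few compounds, and the source may have more. Where it says the series, first, only, none or still open, it means among the compounds named here.

Compound 1 `CC1=CC[C@H](C(C)(C)NC(=S)NN)CC1` is the parent of the set. In a functional assay on NCI/ADR-RES cells (Homo sapiens) for inhibition, read by sulforhodamine B assay, with a stated time of 48 h (a lower number here means a stronger inhibitor of growth, a higher number a weaker inhibitor of growth), compound 1 gives 39300 nM, the highest of the two numbers that are actual numbers here; its nearest neighbour is compound 2 `CC1=CC[C@H](C(C)(C)NC(=S)N/N=C/c2ccccc2O)CC1`, which in this assay gives 3700 nM. Compound 3 `CC1=CC[C@H](C(C)(C)NC(=S)N/N=C/c2ccc(F)cc2)CC1` reaches only the limit of the assay: in this assay compound 3 gives > 100000 nM, a limit rather than a number. Among the compounds with values here, the one measured step within the set, an at least 27-fold higher number from compound 2 to compound 3 (1.43 log units; beyond the scatter), shows that the group on the carbon with a double bond to nitrogen decides whether the number lands well under that of compound 1 or at the limit (the limit of > 100000 nM in this assay, at which 1 of the 3 values shown sits).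

Compound 4 `CC1=CC[C@H](C(C)(C)NC(=S)N/N=C/c2ccco2)CC1` is not yet measured. It differs from compound 1 as follows: a group of 7 heavy atoms (5 carbon, 1 nitrogen, 1 oxygen; one five-membered aromatic ring with 1 hetero atom) in place of one nitrogen atom, on an amide-type nitrogen. Within the data shown here, no measured step starts from compound 1, so the step from compound 2 to compound 3 bears only indirectly: the two condensed analogues bracket compound 1 from both sides, one far lower and one at the limit. The expectation for compound 4 is therefore a small step, a 1.1-fold lower number from compound 1 to compound 4 (0.05 log units; within the scatter), with a wide range either way. Compound 4 is estimated at 35000 nM, range 8000 nM to 100000 nM.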

Compound 4, concentration for 50% growth inhibition: 9800 nM
Compound 4: the middle estimate sits 3.6-fold (0.55 log units) above what was measured, within the range that was stated.
By their numbers in this assay, from the lowest: compound 2; then compound 4; then compound 1. At a limit, above all of these: compound 3.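

In this assay, the furan-2-yl-bearing group on the amide-type nitrogen gives a 4.0-fold lower number from compound 1 to compound 4 (0.60 log units; beyond the scatter), so compound 4 joins compound 2 in printing a number under that of compound 1, and a 2-hydroxyphenyl group is not required for such a number. On the carbon with a double bond to nitrogen, furan-2-yl gives an intermediate result, with a 2.6-fold higher number from compound 2 to compound 4 (0.42 log units; beyond the scatter) and an at least 10-fold lower number from compound 3 to compound 4 (1.00 log units; beyond the scatter), which shows that the outcome at this position is not limited to the two extremes seen with compound 2 and compound 3. Compound 3 stands at a limit and not a number, so the step from it holds only as a bound: the limit of > 100000 nM in this assay, at which 1 of the 4 values shown sits.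

The compounds shown leave open whether the ring itself or its substituent sets these differences, since the hydroxyl and fluoro groups sit on phenyl rings while furan-2-yl carries neither; a plain phenyl, a 2-methoxyphenyl or a thiophen-2-yl group on the same carbon would help separate these factors. They also leave open how far the shared core, with its thiocarbonyl carbon, contributes to these numbers.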